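Notes on the step from compound 2 to compound 3

A few compounds are considered here, and "the series" means these few. Any claim that something is new, unique, unknown or untested is made for them only; others in the source may bear on it.

In a functional assay on RS4-11 cells (Homo sapiens) for inhibition, read by CCK-8 assay, with a stated time of 48 h (on this read-out higher numbers stand for weaker inhibition and lower numbers for stronger inhibition), compound 1 `Cc1ccc(-c2ccsc2S(=O)(=O)NCCNC(=S)Nc2ccc([N+](=O)[O-])cc2)c(Oc2ccc(O)c(O)c2)c1` gives 5100 nM and compound 2 `Cc1ccc(-c2ccsc2S(=O)(=O)NCCNC(=S)Nc2cccc([N+](=O)[O-])c2)c(Oc2ccc(O)c(O)c2)c1` gives 6100 nM on the same read-out, so compound 2 stands level with compound 1 within the scatter. Compound 3 `Cc1ccc(-c2ccsc2S(=O)(=O)NCCNC(=O)Nc2cccc([N+](=O)[O-])c2)c(Oc2ccc(O)c(O)c2)c1` has no number yet. It differs from compound 2 in a single place, on an amine nitrogen whose other neighbours are a saturated chain carbon: a group of 12 heavy atoms (7 carbon, 2 nitrogen, 3 oxygen; one six-membered aromatic ring of carbon only) in place of a group of 12 heavy atoms (7 carbon, 2 nitrogen, 2 oxygen, 1 sulfur; one six-membered aromatic ring of carbon only), on an amine nitrogen and the entering group is (3-nitrophenyl)carbamoyl. Going by the values given here, the only measured step of a 1.2-fold higher number from compound 1 to compound 2 (0.08 log units; within the scatter) exchanges 4-nitrophenyl for 3-nitrophenyl. It lies within the scatter and does not touch the group that changes here, so it gives no direct measure of the new change. Among the compounds with values here, no measured pair carries this exchange. With compound 2 at 6100 nM as the closest anchor, the expected step of a 1.1-fold higher number from compound 2 to compound 3 (0.06 log units; within the scatter) is small, and no firm shift beyond the scatter is expected in this assay although the uncertainty is wide. For compound 3 the estimated value is 7000 nM with 2500 nM to 20000 nM as the expected range.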

Compound 3, half-maximal inhibitory concentration: 9100 nM
Compound 3: the middle estimate sits 1.3-fold (0.11 log units) below what was measured, and the stated range covers the measured number.
By their numbers in this assay, from the lowest: compounds 1, 2 and 3 (each within the scatter of the next).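

In this assay, putting (3-nitrophenyl)carbamoyl on the amine nitrogen, which swaps the sulfur of the leaving group for an oxygen, gives a 1.5-fold higher number from compound 2 to compound 3 (0.17 log units; within the scatter), so the read-out does not separate these two groups. Going by these compounds alone, this is the first look at the group on this nitrogen, since the only measured step so far changed the nitrophenyl group alone; the comparison that also includes that change, a 1.8-fold higher number from compound 1 to compound 3 (0.25 log units; within the scatter), does not separate the compounds either. Within the data shown here, nothing measured so far speaks to the basis of these numbers.

All three compounds carry a nitrophenyl group on this nitrogen through the same kind of linkage, so the series does not yet show how far the number in this assay can move at this position. Going by these compounds, it remains open whether an acetyl or a methanesulfonyl group on the amine nitrogen, an unsubstituted phenyl ring in place of the nitrophenyl, or a longer chain in place of the saturated chain carbon would give a step beyond the scatter.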